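The compounds below may be only part of what the source reports. "The series", "measured", "known", "first", "only" and "open" are said of these compounds alone.

Three compounds built on the same chloro-pyridine core carrying an azetidinylmethoxy side chain have been tested in an assay on membranes from brain with Neuronal acetylcholine receptor; alpha4/beta2 (Rattus norvegicus) as the target; a higher number here means a weaker inhibitor, a lower number a stronger inhibitor. Compound 1, `Fc1ccc(-c2cc(OC[C@@H]3CCN3)cnc2Cl)cn1`, gives 0.0049 nM. Compound 2, `Clc1ncc(OC[C@@H]2CCN2)cc1-c1ccc(Br)nc1`, gives 0.0043 nM. Compound 3, `Fc1cc(-c2cc(OC[C@@H]3CCN3)cnc2Cl)ccn1`, gives 0.0048 nM. All three values lie within the scatter of one another, so none can be called stronger or weaker than the others.

From compound 1 to compound 2 a single change is made: bromo in place of fluoro on an aromatic carbon. This step gives a 1.1-fold lower number from compound 1 to compound 2 (0.06 log units; within the scatter).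

The same kind of change leads from compound 3 to compound 4, `Clc1ncc(OC[C@@H]2CCN2)cc1-c1ccnc(Br)c1`: bromo in place of fluoro on an aromatic carbon. The two halogens sit, in both cases, on an aromatic carbon of a six-membered aromatic ring with 1 nitrogen, next to the ring nitrogen; they differ in that the group in compound 2 is para to a large group whereas in compound 4 it is meta to a large group. How the core of compound 3 differs from the core of compound 1 is not broken down here.

Because the step of a 1.1-fold lower number from compound 1 to compound 2 (0.06 log units; within the scatter) stayed within the scatter, compound 4 is expected to change little from compound 3, by an estimated 1.1-fold lower number from compound 3 to compound 4 (0.03 log units; within the scatter). Compound 4 is therefore expected to give about 0.0045 nM in this assay, most likely between 0.002 nM and 0.01 nM.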

Compound 4, inhibition constant: 0.0033 nM
Beside the measured number, compound 4's estimate is 1.4-fold (0.13 log units) above it, within the range that was stated.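

In this assay, putting bromo in place of fluoro on an aromatic carbon gives a 1.5-fold lower number from compound 3 to compound 4 (0.16 log units; within the scatter), and set beside the earlier case, the two steps do not differ: the same change on two cores in this assay, a 1.1-fold lower number (0.06 log units; within the scatter) from compound 1 to compound 2 and a 1.5-fold lower number (0.16 log units; within the scatter) from compound 3 to compound 4, 1.3-fold (0.11 log units) apart, within the scatter of two such steps. This shows that on these two cores the swap behaves alike, with each step too small to tell apart from the ordinary spread of repeated measurements, so the small size of the step is what carries over from one core to the other. It does not show that either halogen is better, that the two steps share a direction, or that the swap would stay this small on a third core, as two pairs of compounds within the scatter can support none of these claims.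

Every compound shown carries either fluoro or bromo on the ring that changes, which leaves open what a chloro, a methyl, a methoxy or an amine would do in that same place. As far as these compounds go, the chloro on the shared core and the azetidinylmethoxy side chain also stay the same throughout, so how much these very low numbers depend on either of them remains open as well.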